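The source may report more compounds than this note shows. Statements on the series, on what has been measured and on what is new or still open speak of the compounds shown alone.

Of the compounds shown here, two share one core and have been tested in an assay on isolated protein for inhibition of sphingosine kinase 1 (Homo sapiens); a lower number here means a stronger inhibitor, a higher number a weaker inhibitor. Compound 1, whose structure is `CCCCCCCc1nc(-c2ccc([C@@H](NC(=O)[C@H]3NCC[C@@H]3O)C(C)C)cc2)no1`, gives 110 nM. Compound 2, with the structure `CCCCCc1nc(-c2ccc(CNC(=O)[C@H]3NCC[C@@H]3O)cc2)no1`, gives 430 nM. Compound 2 therefore stands at the highest number of the two, and its gap to compound 1 is beyond the usual scatter of this assay, so compound 1 is the stronger inhibitor of the pair.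

Compound 3, with the structure `CC1(c2nc(-c3ccc(CNC(=O)[C@H]4NCC[C@@H]4O)cc3)no2)CCCCC1`, has not yet been measured. It differs from compound 2 in one place: 1-methylcyclohexyl in place of pentyl on an aromatic carbon. The seven-carbon ring group takes the place of the open five-carbon chain on the same carbon of the five-membered aromatic ring.

For compound 3 a modest step toward a lower number is expected, estimated as a 1.7-fold lower number from compound 2 to compound 3 (0.24 log units; within the scatter). The estimate for compound 3 in this assay is 250 nM, within a range from 100 nM to 700 nM.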

Compound 3, half-maximal inhibitory concentration: 210 nM
Beside the measured number, compound 3's estimate is 1.2-fold (0.08 log units) above it; the measured number falls inside the stated range.
By their numbers in this assay, from the lowest: compounds 1 and 3 (each within the scatter of the next); then compound 2.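

In this assay, this position on the five-membered aromatic ring does not depend on an open chain: exchanging pentyl for 1-methylcyclohexyl gives a 2.0-fold lower number from compound 2 to compound 3 (0.31 log units; beyond the scatter), a modest step that lies just beyond the scatter. A bulkier group with a six-membered ring of carbon only is therefore accepted here, and it gives a stronger inhibitor than the open chain in this pair. No measurement shown here explains the step.

The change adds a ring and more carbon in one move, so this pair cannot show which of the two matters. Going by these compounds, how a plain cyclohexyl group, a shorter butyl chain or a piperidine ring, which holds a nitrogen, would compare at this position remains open.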